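The compounds below may be only part of what the source reports. "The series", "measured", "known", "first", "only" and "open" are said of these compounds alone.

Measured so far in a functional assay on NCI-H1993 cells (Homo sapiens) for inhibition, read by CCK-8 assay, with a stated time of 72 h; on this read-out higher numbers stand for weaker inhibition and lower numbers for stronger inhibition:
Compound 1 `CC(NC/N=C/c1ccnn1C)c1ccc2ncccc2c1`: 3290 nM
Compound 2 `CC(NC/N=C/c1cnn(CCO)c1)c1ccc2ncccc2c1`: 148 nM

Of these two, compound 2 has the lower number at 148 nM, and so shows the stronger inhibition in this assay. The next compound, compound 3 `CC(NC/N=C/c1ccncc1)c1ccc2ncccc2c1`, keeps the shared core and changes only the ring on the carbon with a double bond to nitrogen: pyridin-4-yl in place of 1-(2-hydroxyethyl)-1H-pyrazol-4-yl on a carbon with a double bond to nitrogen. Among the measured compounds shown here, only one measured step bears on this place: a 22-fold lower number from compound 1 to compound 2 (1.35 log units; beyond the scatter). That large step shows that the number can move sharply with the group at this carbon. However, it changed both the ring attachment and the substituent, so the data cannot separate the two. Neither compound tests pyridin-4-yl, so the expectation is loose. Compound 3 loses the 1-(2-hydroxyethyl)-1H-pyrazol-4-yl of the better compound, so some loss of inhibition is expected, probably smaller than the measured step. The expected step is a 3.4-fold higher number from compound 2 to compound 3 (0.53 log units; beyond the scatter). For compound 3 the estimated value is 500 nM, with an expected range from 110 nM to 2500 nM.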

Compound 3, half-maximal inhibitory concentration: 614 nM
Compound 3: middle estimate off by 1.2-fold (0.09 log units), on the low side, and the stated range covers the measured number.
By their numbers in this assay, from the lowest: compound 2; then compound 3; then compound 1.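

In this assay, pyridin-4-yl in place of 1-(2-hydroxyethyl)-1H-pyrazol-4-yl on the carbon with a double bond to nitrogen gives a 4.1-fold higher number from compound 2 to compound 3 (0.62 log units; beyond the scatter) and so gives up part of the inhibition, whereas the same ring in place of 1-methyl-1H-pyrazol-5-yl gives a 5.4-fold lower number from compound 1 to compound 3 (0.73 log units; beyond the scatter) and recovers part of it. This position therefore tolerates a six-membered aromatic ring as well as a five-membered one, and compound 3 ranks ahead of compound 1 without any 2-hydroxyethyl chain, although 1-(2-hydroxyethyl)-1H-pyrazol-4-yl remains the best of the three groups shown. Nothing available here explains why the three groups fall in this order.

The compounds shown leave open how much of the advantage of compound 2 belongs to its 2-hydroxyethyl chain and how much to its ring and point of attachment, a question that a 1-methyl-1H-pyrazol-4-yl group at this carbon would address. From the compounds shown here alone, it also remains open whether the hydroxyl group itself matters, or whether a longer chain, an amine or a carboxylic acid on the pyrazole would give a lower or a higher number.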